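Swapping a thiazolylmethyl for a chlorobenzyl on the shared core

The source may hold more compounds than are shown below. What is called first, only, known or untested is meant among the compounds shown, and "the series" means these compounds.

Measured compounds:
- compound 1 `CCOc1cc(C2CCN(C)CC2)ccc1Nc1ncc2c(n1)N(Cc1scnc1C)[C@H](CC)C(=O)N2C`: "not determined" (no result reported)
- compound 2 `CCOc1cc(C2CCN(C)CC2)ccc1Nc1ncc2c(n1)N(Cc1ccccc1)[C@H](CC)C(=O)N2C`: 290 nM
- compound 3 `CCOc1cc(C(=O)NC2CCN(C)CC2)ccc1Nc1ncc2c(n1)N(Cc1ccccc1)[C@H](CC)C(=O)N2C`: 84 nM

All three share one core, and each was tested in an assay on isolated protein for inhibition of serine/threonine-protein kinase PLK1 (Homo sapiens), read by Z'-LYTE, with a stated time of 60 min; on this read-out higher numbers stand for weaker inhibition and lower numbers for stronger inhibition. Compound 1 has no number on this read-out, so its standing among the others cannot be placed. Compound 4 `CCOc1cc(C2CCN(C)CC2)ccc1Nc1ncc2c(n1)N(Cc1cccc(Cl)c1)[C@H](CC)C(=O)N2C` is compound 1 with one change: 3-chlorophenyl in place of 4-methyl-1,3-thiazol-5-yl on a saturated chain carbon bound to a nitrogen on an aromatic ring in a ring. For the measured compounds named here, no measured pair shows exactly this exchange. Going by the values given here, the only measured step, a 3.5-fold lower number from compound 2 to compound 3 (0.54 log units; beyond the scatter), concerns a different part of the molecule and so bears on the present change only loosely; it does show that this series responds to modest edits in a measurable way. Compound 2 is the closest anchor, since it carries the same piperidinyl group as compound 4 and differs from it only by the chlorine on the benzyl ring. Compound 4 is therefore expected to land near compound 2, with wide uncertainty, at about 250 nM, somewhere between 70 nM and 900 nM.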

Compound 4, half-maximal inhibitory concentration: 540 nM
Compound 4: middle estimate off by 2.2-fold (0.33 log units), on the low side, within the range that was stated.
By their numbers in this assay, from the lowest: compound 3; then compounds 2 and 4 (each within the scatter of the next).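

In this assay the exchange of (4-methyl-1,3-thiazol-5-yl)methyl for 3-chlorobenzyl cannot be read as a step, since compound 1 has no number to compare. For the compounds shown here, compound 4 does give a first reading on the benzyl group itself: chloro in place of hydrogen on an aromatic carbon gives a 1.9-fold higher number from compound 2 to compound 4 (0.27 log units; within the scatter) and so, on these two compounds, adding this chlorine leaves no change that can be told from the scatter. No available evidence bears on this result.

On these data alone, whether a methoxy or an amino group in place of the chloro would give a step beyond the scatter stays open. Also open, as far as these compounds go, is whether the change seen in a 3.5-fold lower number from compound 2 to compound 3 (0.54 log units; beyond the scatter) would carry over to a compound with the 3-chlorobenzyl group.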